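Methoxypyridinyl carbonyl in place of methylthiazolyl carbonyl

A few compounds are considered here, and "the series" means these few. Any claim that something is new, unique, unknown or untested is made for them only; others in the source may bear on it.

Measured compounds:
compound 1, `COc1ccc(NC(=O)NS(=O)(=O)N2CCC(CCNC(=O)c3cc(Cl)ccc3OC)CC2)cc1`, 27%
compound 2, `Cc1ncsc1C(=O)NCCC1CCN(S(=O)(=O)NC(=O)NC[C@@H]2C[C@@H]3C=C[C@@H]2C3)CC1`, 11%
compound 3, `Cc1ncccc1C(=O)NCCC1CCN(S(=O)(=O)NC(=O)NC2CCCCC2)CC1`, 16%

Of the compounds shown here, three have been measured in a functional assay on the whole organism (blood) with Rattus norvegicus as the target, with stated times of 24 h and 1 h, at a dose of 5 mg/kg by the intraperitoneal route; on this read-out lower numbers stand for a weaker effect and higher numbers for a stronger effect at the one dose given. In this assay compound 1 gives 27%, compound 2 gives 11% and compound 3 gives 16%. Compound 2 has the lowest of the three numbers; its gap to compound 1 lies beyond the usual scatter, while its gap to compound 3 lies within it, so compound 2 and compound 3 cannot be told apart on this read-out. Within the data shown here, no two of the measured compounds differ in one place only, so no single step between them can be read from the numbers.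

The unmeasured compound 4, `COc1ccc(C(=O)NCCC2CCN(S(=O)(=O)NC(=O)NC[C@@H]3C[C@@H]4C=C[C@@H]3C4)CC2)cn1`, is reached from compound 2 by one change: 6-methoxypyridin-3-yl in place of 4-methyl-1,3-thiazol-5-yl on a carbonyl carbon. Compound 1 also carries a methoxy-bearing aromatic ring on its carbonyl carbon and gives the highest of the three numbers, but it differs from compound 2 in more than one place, so that comparison gives only a loose hint.

For compound 4 in this assay a modest rise is expected, one that may not pass beyond the scatter, the expected step being a number 7 percentage points higher from compound 2 to compound 4 (within the scatter). The estimate for compound 4 is 18%, with a range from 5% to 35%.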

Compound 4, a percentage reported as activity, at one dose (the size of the read-out at that dose, not a potency): 11%
Compound 4: the middle estimate sits 7 percentage points above what was measured; the range from low to high includes it.
By their numbers in this assay, from the lowest: compounds 2, 4 and 3 (each within the scatter of the next); then compound 1.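

Among these compounds, this is the first comparison that changes one place only, and it isolates the group on a carbonyl carbon whose other neighbour is an amide-type nitrogen. In this assay, 6-methoxypyridin-3-yl in place of 4-methyl-1,3-thiazol-5-yl gives no change at the digits printed from compound 2 to compound 4 (within the scatter), so this exchange does not separate the two compounds on this read-out, even though a five-membered aromatic ring with 2 hetero atoms gives way to a six-membered aromatic ring with 1 hetero atom and the group grows from 6 to 8 heavy atoms, while both groups have 2 hydrogen-bond acceptors and 0 donors. No supporting evidence bears on this result.

This single step comes from one pair sharing the same remainder of the structure, so it cannot show whether the exchange would give the same result elsewhere in the series. It also leaves open whether a different group on the same carbonyl carbon, such as a carboxylic acid-bearing phenyl ring or an aminopyridine, would shift the number in this assay beyond the scatter.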